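The source may hold more compounds than are shown below. What is called first, only, known or untested is meant among the compounds shown, and "the series" means these compounds.

Among the measured compounds shown here, only two compounds have been tested so far in an ADME assay on microsomes from liver (Rattus norvegicus) for metabolic stability, read by LC-MS, using NADPH, with a stated time of 30 min, tested at 0.1 uM, in the presence of a further agent that is not named here; on this read-out lower numbers stand for a less stable compound and higher numbers for a more stable compound. Compound 1 `Nc1ccc(-c2cnc(N)c(-c3ccc(N)nc3)n2)cn1` gives > 90%, which is a limit of the assay and not a number. Compound 2 `Nc1ncc(-c2ccc(C(=O)N3CC(O)C3)cc2)nc1-c1ccc(C(F)(F)F)cc1` gives > 90%, which is also a limit. For the measured compounds named here, compound 2 therefore stands with the only other tested compound at the limit of > 90% in this assay, at which 2 of the 2 values shown sit, and its exact value remains unknown.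

Compound 3 `NC(=O)c1ccc(-c2cnc(N)c(-c3ccc(C(F)(F)F)cc3)n2)cc1` has not yet been measured. It differs from compound 2 in one place, with amino in place of 3-hydroxyazetidin-1-yl on a carbonyl carbon. Going by the values given here, no measured pair shows the size of such a change, so the expectation starts from compound 2 and its limit of > 90%. The expected result is a number no higher from compound 2 to compound 3 (the limit leaves the size open), an estimated step no larger than the usual scatter, with no direction favoured. For compound 3 the estimate is 90%, with an expected range from 72% to 100%.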

Compound 3, percent of the compound remaining: > 90%
Compound 3: a limit, no number (the forecaster's own chance of this, stated with the estimate: 50%); the middle value sits exactly at the limit.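

Among the compounds shown here, compound 2 and compound 3 both give a limit and not a number, so no step between them can be read: the limit of > 90% in this assay, at which 3 of the 3 values shown sit. The compounds shown leave open how stable each one really is, and whether amino in place of 3-hydroxyazetidin-1-yl changes that stability at all.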